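The compounds below may be only part of what the source reports. "The series", "measured", "known", "first", "only" and "open" are said of these compounds alone.

Compound 1 `CCN(CCCCCCOc1ccc(C(=O)/C=C/c2ccc(N(C)C)cc2)c(O)c1)Cc1ccccc1` and compound 2 `CCN(CCCCCCOc1ccc(C(=O)/C=C/c2ccc(N(C)C)cc2)c(O)c1)Cc1ccccc1N(C)C` share one core. In an assay on isolated protein for inhibition of Amine oxidase [flavin-containing] A (Homo sapiens) (on this read-out higher numbers stand for weaker inhibition and lower numbers for stronger inhibition), compound 1 gives 31600 nM, and compound 2 gives 37800 nM. The change between them is dimethylamino in place of hydrogen on an aromatic carbon, and it made a 1.2-fold higher number from compound 1 to compound 2 (0.08 log units; within the scatter). Compound 3 `CCN(CCCOc1ccc(C(=O)/C=C/c2ccccc2)c(O)c1)Cc1ccccc1N(C)C` rests on a different core; how that core differs from the core of compound 1 is not broken down here. In this assay compound 3 gives 67800 nM. Compound 4 `CCN(CCCOc1ccc(C(=O)/C=C/c2ccc(N(C)C)cc2)c(O)c1)Cc1ccccc1N(C)C` has not yet been measured. It differs from compound 3 by dimethylamino in place of hydrogen on an aromatic carbon. Going by the values given here, this is the same kind of change as the one made from compound 1 to compound 2, yet the place is not identical: in compound 4 the entering group sits para to a large group, whereas in compound 2 it sits ortho to a large group. Because a 1.2-fold higher number from compound 1 to compound 2 (0.08 log units; within the scatter) lay within the scatter, a similarly small step is expected here, namely a 1.1-fold higher number from compound 3 to compound 4 (0.04 log units; within the scatter). Compound 4 is therefore estimated at 75000 nM, most likely between 35000 nM and 160000 nM.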

Compound 4, half-maximal inhibitory concentration: 23600 nM
For compound 4 the middle estimate is 3.2-fold (0.50 log units) above the measured one; measured number outside the range, below it.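

In this assay, putting dimethylamino on the aromatic ring gave a 2.9-fold lower number from compound 3 to compound 4 (0.46 log units; beyond the scatter), so on this core the change strengthened inhibition. The step did not carry over at the same size from one core to the other: the same change on two cores in this assay, a 1.2-fold higher number (0.08 log units; within the scatter) from compound 1 to compound 2 and a 2.9-fold lower number (0.46 log units; beyond the scatter) from compound 3 to compound 4, 3.4-fold (0.54 log units) apart, beyond the scatter of two such steps. Going by these compounds alone, this rests on only two pairs, and the entering group sits in a different place in each, so the data show that the step cannot simply be transferred but not which difference between the pairs is responsible.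

On these data alone, it remains open whether another group at the same place on the ring, such as methoxy or diethylamino, would give a similar step. As far as these compounds go, it is also open how the dimethylamino step would behave on other chain lengths.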